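Nitro for Cyano on a Benzyl-Triazole Oxime Ether

The source may hold more compounds than are shown below. What is called first, only, known or untested is meant among the compounds shown, and "the series" means these compounds.

This account follows a single change on the benzyl ring of a shared core. Compound 1 `O=[N+]([O-])c1ccc(Cn2cc(CO/N=C/c3c(-c4ccc(F)cc4)nc4ccc(Br)cn34)nn2)cc1` and compound 2 `N#Cc1ccc(Cn2cc(CO/N=C/c3c(-c4ccccc4)nc4ccc(Br)cn34)nn2)cc1` were both tested in a functional assay on the whole organism (strain NMRI) with Mus musculus as the target, in the maximal electroshock model, with a stated time of 4 h; a lower number here means that less compound is needed, a higher number that more compound is needed for the effect. In this assay compound 1 gives 100 mg/kg, and compound 2 gives 100 mg/kg. Compound 2 therefore stands level with compound 1 at the digits reported; the two values lie within the scatter of one another, so no order between them can be read from these numbers.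

Compound 3 `O=[N+]([O-])c1ccc(Cn2cc(CO/N=C/c3c(-c4ccccc4)nc4ccc(Br)cn34)nn2)cc1` has not yet been measured in this assay. It differs from compound 2 in one place: nitro in place of cyano on an aromatic carbon. For the measured compounds named here, no measured pair in this set isolates this change, so the expectation rests only on the two values above. Since compound 1 and compound 2 each give the same reading, the author expects the step of no change at the digits printed from compound 2 to compound 3 (within the scatter) to be none beyond the scatter. For compound 3 the estimated minimum effective dose in this assay is 100 mg/kg, with a range from 50 mg/kg to 200 mg/kg.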

Compound 3, minimum effective dose: 40 mg/kg
Beside the measured number, compound 3's estimate is 2.5-fold (0.40 log units) above it, outside the stated range (below it).
By their numbers in this assay, from the lowest: compound 3; then compounds 1 and 2 (each within the scatter of the next).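

In this assay the 4-cyanobenzyl to 4-nitrobenzyl change gives a 2.5-fold lower number from compound 2 to compound 3 (0.40 log units; beyond the scatter) and so shows that the group held at this place on the benzyl ring can move the minimum effective dose beyond the scatter, which the level readings of the two earlier compounds could not show. Hydrogen in place of fluoro on an aromatic carbon, with the nitro kept, gives a 2.5-fold lower number from compound 1 to compound 3 (0.40 log units; beyond the scatter) and thus shows a second place in the molecule where a single change registers, since compounds 1 and 2 differ from each other in both places and neither change could be isolated from that pair. Nothing in the data shown accounts for either step.

The compounds shown leave open whether the step from fluoro to hydrogen would also appear with cyano on the benzyl ring, and so whether the two changes act independently of one another. On these data alone, it also remains open how an amine, a carboxylic acid or a methoxy group at this same place on the benzyl ring would compare with nitro and cyano.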